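Compound 1 to compound 3: one group exchanged

This account rests on a few compounds, and the source may have more. Where it says the series, first, only, none or still open, it means among the compounds named here.

For the measured compounds named here, in a functional assay on RKO cells (Homo sapiens) for cytotoxicity, read by resazurin assay, with a stated time of 72 h (a higher number here means a weaker inhibitor, a lower number a stronger inhibitor), compound 1 `Cc1nc2ccccc2n1-c1csc(Nc2cccc(Br)c2)n1` gives 85000 nM as the only numeric reading so far. Compound 2 `Cc1nccn1-c1csc(Nc2ccc(S(N)(=O)=O)cc2)n1` reads > 100000 nM as a limit of the assay, not a number. Compound 3 `COc1ccc(Nc2nc(-n3c(C)nc4ccccc43)cs2)cc1` keeps the core of compound 1 and carries 4-methoxyphenyl in place of 3-bromophenyl on a nitrogen on an aromatic ring. Going by the values given here, no measured step bears on this change, so no shift beyond the scatter is expected in this assay from the reading of compound 1. The expected 1.2-fold lower number from compound 1 to compound 3 (0.08 log units; within the scatter) stays small. Compound 3 is estimated at 70000 nM (30000 nM to 100000 nM).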

Compound 3, half-maximal inhibitory concentration: 52500 nM
The estimate for compound 3 lay 1.3-fold (0.12 log units) above the measured number, and the stated range covers the measured number.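

In this assay, 4-methoxyphenyl in place of 3-bromophenyl on a nitrogen on an aromatic ring gives a 1.6-fold lower number from compound 1 to compound 3 (0.21 log units; within the scatter). For the compounds shown here, this is the only readable step at this position, and on the shared core the exchange of these two groups does not separate the readings beyond the scatter. Compound 2 stays a limit of the assay, not a number: the limit of > 100000 nM in this assay, at which 1 of the 3 values shown sits.

Open: whether an amine or a carboxylic acid on the phenyl ring would move the reading beyond the scatter. Going by these compounds, whether any change elsewhere on the shared core would do so also remains open.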